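Adding a Second Chlorine to a Chloropurine Benzyl Series

The source may report more compounds than this note shows. Statements on the series, on what has been measured and on what is new or still open speak of the compounds shown alone.

Three compounds were tested in a functional assay on HCC 2998 cells (Homo sapiens) for cytotoxicity, read by sulforhodamine B assay, with a stated time of 48 h; on this read-out higher numbers stand for weaker inhibition of growth and lower numbers for stronger inhibition of growth. Compound 1 `ClCc1ccccc1Cn1cnc2c(Cl)ncnc21` gives 1660 nM in this assay. Compound 2 `ClCc1cccc(Cn2cnc3c(Cl)ncnc32)c1` gives 400 nM. Compound 3 `ClCc1ccc(Cn2cnc3nc(Cl)nc(Cl)c32)cc1`, whose core carries two chlorines, gives 2040 nM. Compound 2 thus holds the lowest number of the three, and its gaps to compound 1 and to compound 3 both lie beyond the scatter. The three differ at once in the placement of the chloromethyl group on the benzyl ring and in the number of chlorines on the core, so no single change can be read from them. Compound 4 `ClCc1cccc(Cn2cnc3c(Cl)nc(Cl)nc32)c1` keeps the benzyl portion of compound 2 and differs from it only by chloro in place of hydrogen on an aromatic carbon. Among the measured compounds shown here, no measured pair isolates this change; compound 3 carries the second chlorine but also a different benzyl placement, so its value together with that of compound 2 cannot be split into parts. A modest shift toward a higher number is expected, a 1.8-fold higher number from compound 2 to compound 4 (0.24 log units; within the scatter), though it may well fall within the scatter. Compound 4 is accordingly estimated to give about 700 nM, within a range from 250 nM to 2000 nM.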

Compound 4, concentration for 50% growth inhibition: 1620 nM
Beside the measured number, compound 4's estimate is 2.3-fold (0.36 log units) below it; the range from low to high includes it.
By their numbers in this assay, from the lowest: compound 2; then compounds 4, 1 and 3 (each within the scatter of the next).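

In this assay, among the compounds shown here, the exchange of hydrogen for chloro on the aromatic carbon between two ring nitrogen atoms gives a 4.1-fold higher number from compound 2 to compound 4 (0.61 log units; beyond the scatter) and is the first step in this set that isolates a single change. With the benzyl portion held constant, this one added chlorine atom moves the number beyond the scatter, toward weaker inhibition of growth, so this position is not indifferent to substitution. Nothing among the available data accounts for the size or direction of this step.

The compounds shown do not reveal whether the step is particular to chloro, since an amine, a methoxy group or a methyl group on the same carbon would be needed to tell. They also leave open whether the same exchange has a similar effect with the chloromethyl group placed as in compound 1.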